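This account rests on a few compounds, and the source may have more. Where it says the series, first, only, none or still open, it means among the compounds named here.

In a functional assay on A549 cells (Homo sapiens) for cytotoxicity, read by MTT assay, with a stated time of 72 h (a lower number here means a stronger inhibitor, a higher number a weaker inhibitor), compound 1 `COc1cc(/C=C2\CN(C)C/C(=C\c3cc(OC)c(OC)c(OC)c3)C2=O)cc(OC)c1OC` gives 1700 nM and compound 2 `CCN1C/C(=C\c2cc(OC)c(OC)c(OC)c2)C(=O)/C(=C/c2cc(OC)c(OC)c(OC)c2)C1` gives 4200 nM, a gap recorded as a 2.5-fold higher number from compound 1 to compound 2 (0.39 log units; beyond the scatter). Compound 3 `COc1cc(/C=C2\CN(C(=O)CCC(=O)O)C/C(=C\c3cc(OC)c(OC)c(OC)c3)C2=O)cc(OC)c1OC`, which carries (2-carboxyethyl)carbonyl on the amine nitrogen in the ring, gives 17900 nM. That is the highest of the three numbers, and so compound 3 is the weakest inhibitor measured in this assay.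

Compound 4 `CCC(=O)N1C/C(=C\c2cc(OC)c(OC)c(OC)c2)C(=O)/C(=C/c2cc(OC)c(OC)c(OC)c2)C1` keeps the shared core and the carbonyl on that nitrogen, but has hydrogen in place of carboxy on a saturated chain carbon, two bonds along the chain from a carbonyl carbon. The side chain thus changes from (2-carboxyethyl)carbonyl to propanoyl.

Among the compounds with values here, two measured steps bear on this change, both going towards the carboxy-bearing chain: an 11-fold higher number from compound 1 to compound 3 (1.02 log units; beyond the scatter) and a 4.3-fold higher number from compound 2 to compound 3 (0.63 log units; beyond the scatter). Within the data shown here, neither isolates the carboxy group, and no measured compound has an acyl group on that nitrogen without it. Part of the gap may therefore stay with the carbonyl, so a reversal of modest size is expected rather than a full return to the values of compound 1 or compound 2. The expected change is a 3.6-fold lower number from compound 3 to compound 4 (0.55 log units; beyond the scatter). Compound 4 is estimated at 5000 nM, with an expected range from 1500 nM to 14000 nM.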

Compound 4, half-maximal inhibitory concentration: 800 nM
Estimate against measurement, compound 4: 6.3-fold (0.80 log units) above; measured number below the stated range.
By their numbers in this assay, from the lowest: compound 4; then compound 1; then compound 2; then compound 3.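

In this assay, taking away the carboxy group alone, on a saturated chain carbon two bonds along the chain from a carbonyl carbon, gives a 22-fold lower number from compound 3 to compound 4 (1.35 log units; beyond the scatter), so this single change accounts for a large step that the earlier compounds could only show mixed with a change of the whole group on the amine nitrogen in the ring. The carbonyl on that nitrogen does not by itself carry a loss, as propanoyl in place of ethyl gives a 5.3-fold lower number from compound 2 to compound 4 (0.72 log units; beyond the scatter) and propanoyl in place of methyl gives a 2.1-fold lower number from compound 1 to compound 4 (0.33 log units; beyond the scatter), which makes compound 4 the strongest inhibitor of the four compounds shown and reverses the direction that compound 3 had suggested for an acyl group at this nitrogen. Nothing shown here gives a measured reason for the size of these steps.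

Whether the carboxy step is specific to the carboxylic acid remains open, as no methyl ester or primary amide at the end of the chain is among these compounds. It is equally unknown how the number would respond to acetyl or to a longer chain such as butanoyl on the same nitrogen.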